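Removing a Fluoro Group from an Aryl Sulfonyl Piperazine

This account rests on a few compounds, and the source may have more. Where it says the series, first, only, none or still open, it means among the compounds named here.

This account follows two compounds measured in an ADME assay on microsomes from liver (Mus musculus) for metabolic stability, read by LC-MS, using NADPH, tested at 10 uM (on this read-out higher numbers stand for a longer-lived compound and lower numbers for a shorter-lived compound), and another that has not yet been run. Compound 1, `Cc1cc(F)ccc1S(=O)(=O)N1CCN(c2ccc(C(=O)NCc3ccc(F)cc3)nn2)CC1`, gives 0.25 h in this assay. Compound 2, `O=C(NCc1ccccc1)c1ccc(N2CCC(S(=O)(=O)c3cccc(Cl)c3Cl)CC2)nn1`, gives 0.333 h in the same read-out. For the measured compounds named here, the two numbers lie within the scatter of each other, so nothing separates compound 1 from compound 2 in this assay, and compound 1 has no standing of its own on the numbers so far.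

Compound 3, `Cc1ccccc1S(=O)(=O)N1CCN(c2ccc(C(=O)NCc3ccc(F)cc3)nn2)CC1`, is the next compound to be measured. It differs from compound 1 in one place: hydrogen in place of fluoro on an aromatic carbon. The change sits on the aromatic carbon that is meta to a methyl group and para to a large group.

Going by the values given here, no step between measured compounds is available to guide this. Among the compounds with values here, with only the single change of a fluoro for a hydrogen, compound 3 is expected to stay close to compound 1, with any step a 1.1-fold lower number from compound 1 to compound 3 (0.06 log units; within the scatter) small and no larger than the scatter. The estimate for compound 3 in this assay is 0.22 h, within a range from 0.1 h to 0.5 h.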

Compound 3, half-life: 0.433 h
Compound 3: middle estimate off by 2.0-fold (0.29 log units), on the low side; the range from low to high includes it.
By their numbers in this assay, from the lowest: compounds 1, 2 and 3 (each within the scatter of the next).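

In this assay, for the compounds shown here, hydrogen in place of fluoro on the aromatic carbon that is meta to a methyl group and para to a large group gives a 1.7-fold higher number from compound 1 to compound 3 (0.24 log units; within the scatter) and so provides the first step in this account that isolates a single place. The 4-fluoro-2-methylphenyl and 2-methylphenyl forms of the sulfonyl group therefore cannot be told apart on this read-out, and the fluoro on this carbon is not shown to matter here, in either direction. No measurement in hand bears on why these two compounds read as they do.

Going by these compounds, this single step tests only the exchange of fluoro and hydrogen at one carbon, so it remains open whether a larger group there, such as methoxy, a nitrile or an amine, would separate from compound 3 by more than the scatter. On these data alone, it is equally open whether the fluoro on the benzyl group of the amide, which compound 1 and compound 3 share, behaves in the same way when exchanged for hydrogen.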